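Cyclohexyl in Place of Methyl on the Shared Core

This account rests on a few compounds, and the source may have more. Where it says the series, first, only, none or still open, it means among the compounds named here.

compound 1 `COC(=O)c1nc(C)n(-c2ccc(C(F)(F)F)cc2)n1`: 9100 nM
compound 2 `COC(=O)c1nc(C)n(-c2ccc(OC)cc2)n1`: > 100000 nM (a limit, not a number)

In a functional assay on Jurkat cells (Homo sapiens) for inhibition, read by MTT assay, with a stated time of 72 h (on this read-out lower numbers stand for stronger inhibition of growth and higher numbers for weaker inhibition of growth), compound 1 carries the only number shown. For compound 2 the assay gives only a limit, (the limit of > 100000 nM in this assay, at which 1 of the 2 values shown sits). Among the measured compounds shown here, the one measured step, an at least 10-fold higher number from compound 1 to compound 2 (1.04 log units; beyond the scatter), changes a group on the benzene ring and so does not bear on the new compound 3 `COC(=O)c1nc(C2CCCCC2)n(-c2ccc(C(F)(F)F)cc2)n1`, whose change is cyclohexyl in place of methyl on an aromatic carbon. For the measured compounds named here, with no step touching this position, compound 3 is expected to sit near compound 1, a step of a 1.0-fold lower number from compound 1 to compound 3 (0.00 log units; within the scatter); its estimated value is 9000 nM, within 2000 nM to 50000 nM.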

Compound 3, concentration for 50% growth inhibition: > 100000 nM
Compound 3: a limit, no number; the forecaster's own chance of this, stated with the estimate: 25%; middle value at least 11-fold (1.04 log units) away from the limit.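

In this assay, the aromatic carbon between two ring nitrogen atoms turns out not to be a neutral place for change: cyclohexyl in place of methyl gives an at least 10-fold higher number from compound 1 to compound 3 (1.04 log units; beyond the scatter) on the shared core. Of the two groups shown at this position, only methyl, in compound 1, gives a number. As far as these compounds go, for compound 3 the value is a limit, not a number, so how far the loss goes stays unknown: the limit of > 100000 nM in this assay, at which 2 of the 3 values shown sit.

From the compounds shown here alone, whether ethyl or isopropyl at this position would keep the growth inhibition of compound 1 remains open. So does the effect of an amine or a carboxylic acid there.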